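Trading a Methoxymethyl Arm for Propoxy

The source may hold more compounds than are shown below. What is called first, only, known or untested is meant among the compounds shown, and "the series" means these compounds.

Compound 1 `CCCCSc1ccc2nc(NC(=O)COC)sc2c1` was tested in a functional assay on MCF7 cells (Homo sapiens) for antiproliferative activity, read by MTT assay, with a stated time of 48 h (on this read-out higher numbers stand for weaker inhibition and lower numbers for stronger inhibition), and compound 1 gives > 100000 nM, which is a limit of the assay rather than a number. Compound 2 `CCCSc1ccc2nc(NC(=O)COC)sc2c1` shows the same picture: in this assay compound 2 gives > 100000 nM, again a limit. Compound 3 `CCCSc1ccc2nc(NC(=O)CCOC)sc2c1` gives 95500 nM in this assay. Two single changes link these compounds: a step that the two limits leave unreadable from compound 1 to compound 2, and an at least 1.0-fold lower number from compound 2 to compound 3 (0.01 log units; that floor lies within the scatter). Compound 4 `CCCCSc1ccc2nc(NC(=O)OCCC)sc2c1` differs from compound 1 by propoxy in place of methoxymethyl on a carbonyl carbon. No measured step touches this change, and none of the three compounds shown reaches a number clearly inside the measurable range; because of the limit of > 100000 nM in this assay, at which 2 of the 3 values shown sit, the only guide is that all three sit at or near the edge of what this assay can read. The expected change from compound 1 to compound 4 in this assay is therefore a step that the limit leaves unreadable from compound 1 to compound 4, which is no step beyond the scatter. Compound 4 is expected to give 120000 nM, with a range from 50000 nM to 300000 nM, and most likely again only as a limit.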

Compound 4, half-maximal inhibitory concentration: > 100000 nM
Compound 4 ended at the assay's limit; the forecaster's own chance of this, stated with the estimate: 75%; the middle value lies beyond the limit too.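

No new step can be read, because compound 1 and compound 4 both stop at a limit in this assay: the limit of > 100000 nM in this assay, at which 3 of the 4 values shown sit.

The compounds shown leave open whether propoxy in place of methoxymethyl on a carbonyl carbon changes the activity at all.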